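This account rests on a few compounds, and the source may have more. Where it says the series, first, only, none or still open, it means among the compounds named here.

Compound 1 `O=c1ccoc2cc(OCc3cn(Cc4cccc(F)c4)nn3)ccc12` carries a 3-fluorobenzyl group on the shared core. In a functional assay on A549 cells (Homo sapiens) for cytotoxicity, read by MTT assay, with a stated time of 48 h (on this read-out higher numbers stand for weaker inhibition and lower numbers for stronger inhibition), compound 1 gives only a limit, > 100000 nM, as noted in the limit of > 100000 nM in this assay, at which 1 of the 2 values shown sits. Compound 2 `O=c1ccoc2cc(OCc3cn(Cc4cccc([N+](=O)[O-])c4)nn3)ccc12` is the nitro analogue, and in this assay compound 2 gives 9450 nM. Going by the values given here, the only measured step, an at least 10-fold lower number from compound 1 to compound 2 (1.02 log units; beyond the scatter), concerns a different change. Compound 3 `O=c1ccoc2cc(OCc3cn(Cc4ccccc4F)nn3)ccc12` differs from compound 1 by 2-fluorophenyl in place of 3-fluorophenyl on a saturated chain carbon bound to an aromatic nitrogen. Among the compounds with values here, no measured step covers a move of the fluorine, so no step beyond the scatter is expected. For compound 3 the expected step is a step that the limit leaves unreadable from compound 1 to compound 3. For compound 3 the estimate in this assay is 150000 nM, within 50000 nM to 500000 nM, most likely again a limit.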

Compound 3, half-maximal inhibitory concentration: 10800 nM
Estimate against measurement, compound 3: 14-fold (1.14 log units) above; the whole stated range lies above it.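

The move of the fluorine alone counts at this place: 2-fluorophenyl in place of 3-fluorophenyl gives a clear gain in cytotoxicity (an at least 9.2-fold lower number from compound 1 to compound 3 (0.96 log units; beyond the scatter)). Compound 3 and the nitro analogue cannot be told apart (a 1.1-fold higher number from compound 2 to compound 3 (0.06 log units; within the scatter)), so a nitro group is not needed for this level of cytotoxicity in the pair shown. Compound 1 stands at a limit, so the first step has a lower bound on its size only: the limit of > 100000 nM in this assay, at which 1 of the 3 values shown sits.

Open, going by these compounds, is whether a chlorine, a methoxy group or an amine on the phenyl ring would hold this level. Also open, on these data alone, is whether the nitro group responds to the same move as the fluorine.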